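Series notes: mirror-image of compound 1 in the rat assay

The source may hold more compounds than are shown below. What is called first, only, known or untested is meant among the compounds shown, and "the series" means these compounds.

Three compounds of this short series carry measurements in a functional assay on the whole organism (strain Sprague-Dawley) with Rattus norvegicus as the target; a lower number here means that less compound is needed, a higher number that more compound is needed for the effect. Compound 1 `CCC[C@H](C(=O)NC(N)=O)C(C)C` gives 37 mg/kg and sits at the low end of the three numbers, though not beyond the scatter of either neighbour. Compound 2 `CCC[C@H](C(N)=O)C(C)C` gives 38 mg/kg in this assay, and compound 3 `CC(C)C(C(N)=O)C(C)C` gives 60 mg/kg. Among the compounds with values here, the only single-point step measured is a 1.0-fold higher number from compound 1 to compound 2 (0.01 log units; within the scatter), which left the read-out unmoved.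

Compound 4 `CCC[C@@H](C(=O)NC(N)=O)C(C)C` differs from compound 1 as follows: the two compounds have the same atoms and bonds and differ only in configuration as drawn: 1 of 1 stereo elements differ; a stereocentre at a saturated chain carbon is drawn S in compound 1 and R in compound 4. Within the data shown here, no measured step changes configuration, so the one measured step does not bear on this change, and the pair compound 2 and compound 3 also differ only in chain branching, not in stereochemistry. There is therefore no basis in these numbers for a direction; the expectation for compound 4 is a step of a 1.2-fold higher number from compound 1 to compound 4 (0.09 log units; within the scatter) in this assay, with a wide range to allow for a mirror image behaving differently. Compound 4 is estimated at 45 mg/kg, between 20 mg/kg and 110 mg/kg.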

Compound 4, dose for half-maximal effect: 22 mg/kg
Estimate against measurement, compound 4: 2.0-fold (0.31 log units) above; the range from low to high includes it.
By their numbers in this assay, from the lowest: compounds 4, 1, 2 and 3 (each within the scatter of the next, the first and the last beyond it).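

Inverting the one stereocentre is the first change of configuration measured in the series, and in this assay it gives a 1.7-fold lower number from compound 1 to compound 4 (0.23 log units; within the scatter). The drawn configuration at this saturated chain carbon therefore does not separate this pair in this assay, so the read-out gives no preference for S or R here. Any reading of this step concerns the stereocentre alone: the fact that compounds 1 and 4 differ only in the configuration as drawn

Still open, as far as these compounds go, is whether the same holds for the mirror image of compound 2, which lacks the carbamoyl on the amide-type nitrogen. Also open, from the compounds shown here alone, is whether the two configurations would stay within the scatter of each other with a longer chain on the stereocentre, or with a carboxylic acid in place of the amide-type group.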